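Expanding the azetidine ring on the amide of compound 1

A few compounds are considered here, and "the series" means these few. Any claim that something is new, unique, unknown or untested is made for them only; others in the source may bear on it.

Measured compounds:
compound 1 `CCN(CC)S(=O)(=O)c1ccc(S(=O)(=O)N2CCC[C@@H](C(=O)NC3CN(C(=O)OC(C)(C)C)C3)C2)cc1`: 200 nM
compound 2 `CCOC(=O)[C@@H]1CCCN(S(=O)(=O)c2ccc(S(=O)(=O)N(CC)C(C)C)cc2)C1`: 1000 nM
compound 3 `CCN(CC)C(=O)[C@@H]1CCCN(S(=O)(=O)c2ccc(S(=O)(=O)N(CC)CC)cc2)C1`: 6400 nM

In a functional assay on MIA PaCa-2 cells (Homo sapiens) for inhibition, read by MTT assay, with a stated time of 7 days (on this read-out higher numbers stand for weaker inhibition and lower numbers for stronger inhibition), compound 1 stands lowest of the three numbers. Compound 2 sits nearer to it, while compound 3 lies furthest away, the step being a 32-fold higher number from compound 1 to compound 3 (1.51 log units; beyond the scatter) for diethylamino in place of (1-(tert-butoxycarbonyl)azetidin-3-yl)amino on the carbonyl carbon.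

Compound 4 `CCN(CC)S(=O)(=O)c1ccc(S(=O)(=O)N2CCC[C@@H](C(=O)N[C@H]3CCN(C(=O)OC(C)(C)C)C3)C2)cc1` differs from compound 1 by 1-(tert-butoxycarbonyl)pyrrolidin-3-yl in place of 1-(tert-butoxycarbonyl)azetidin-3-yl on an amide-type nitrogen. Within the data shown here, the only step measured on this part of the molecule is the large one to compound 3, which removes the whole saturated ring and its carbamate rather than enlarging the ring by one carbon. Among the measured compounds shown here, that step shows the amide substituent matters, but gives no direct precedent for an azetidine-to-pyrrolidine change, and no measured pair speaks to ring size here. The four-membered ring and the five-membered ring carry the same tert-butoxycarbonyl group and the same acceptor count, so the step is expected to be modest, most likely within or just beyond the scatter, with slightly more room on the weaker side.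

Compound 4 is therefore estimated at 300 nM, with a range of 90 nM to 1000 nM, an expected step of a 1.5-fold higher number from compound 1 to compound 4 (0.18 log units; within the scatter).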

Compound 4, half-maximal inhibitory concentration: 100 nM
Compound 4: middle estimate off by 3.0-fold (0.48 log units), on the high side, and the stated range covers the measured number.
By their numbers in this assay, from the lowest: compounds 4 and 1 (each within the scatter of the next); then compound 2; then compound 3.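

In this assay, among these compounds, the first direct reading of ring size on this amide-type nitrogen is a 2.0-fold lower number from compound 1 to compound 4 (0.30 log units; within the scatter) and so lies within the scatter, which means that 1-(tert-butoxycarbonyl)pyrrolidin-3-yl serves here as well as 1-(tert-butoxycarbonyl)azetidin-3-yl. The earlier step of a 32-fold higher number from compound 1 to compound 3 (1.51 log units; beyond the scatter) showed only that diethylamino does not match the azetidine group, whereas this pair shows that the position does not depend on the four-membered ring itself. Nothing available explains why the two rings read alike.

On these data alone, whether the opposite configuration at the defined stereocentre of compound 4 would read the same remains open. So does the fate of the number with 1-(tert-butoxycarbonyl)piperidin-4-yl on this nitrogen, or with the free secondary amine left once the tert-butoxycarbonyl group is gone.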